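The source may hold more compounds than are shown below. What is called first, only, known or untested is meant among the compounds shown, and "the series" means these compounds.

Values in a functional assay on MGC-803 cells (Homo sapiens) for inhibition, read by sulforhodamine B assay; a higher number here means a weaker inhibitor, a lower number a stronger inhibitor:
- Compound 1 `CCCc1ccc(NC2=CC(=O)c3nc4n(c3C2=O)[C@H]2OC[C@@H](O)[C@H]2OC4)cc1`: 1560 nM
- Compound 2 `O=C1C=C(NC2CCCC2)C(=O)c2c1nc1n2[C@H]2OC[C@@H](O)[C@H]2OC1`: > 8000 nM

For compound 2 there is no number, only a limit of the assay, > 8000 nM.

Compound 3 `CCOc1ccc(NC2=CC(=O)c3nc4n(c3C2=O)[C@H]2OC[C@@H](O)[C@H]2OC4)cc1` carries 4-ethoxyphenyl in place of cyclopentyl on an amine nitrogen.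

Among the measured compounds shown here, one measured step bears on this change: an at least 5.1-fold higher number from compound 1 to compound 2 (0.70 log units; beyond the scatter), with cyclopentyl in place of 4-propylphenyl on an amine nitrogen. Restoring a substituted phenyl group should therefore run the other way in this assay, by a similar size, and the expected step is an at least 4.4-fold lower number from compound 2 to compound 3 (0.64 log units; beyond the scatter).

For compound 3 the estimate is 1800 nM, with an expected range from 600 nM to 5500 nM.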

Compound 3, half-maximal inhibitory concentration: 1110 nM
Compound 3: middle estimate off by 1.6-fold (0.21 log units), on the high side, within the range that was stated.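

On the amine nitrogen, the gain from a substituted phenyl group is not confined to 4-propylphenyl: in this assay, 4-ethoxyphenyl in place of cyclopentyl gives an at least 7.2-fold lower number from compound 2 to compound 3 (0.85 log units; beyond the scatter). Ethoxy in place of propyl on the aromatic carbon gives a 1.4-fold lower number from compound 1 to compound 3 (0.15 log units; within the scatter), so the two groups cannot be told apart here. The first step's size is only a bound, since compound 2 has a limit of the assay and no number: the limit of > 8000 nM in this assay, at which 1 of the 3 values shown sits.

On these data alone, whether a plain phenyl or a benzyl group would hold this level stays open. So does the effect of an amine, a carboxylic acid or a longer chain on the aromatic carbon.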